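Adding a chloro to the pendant phenyl of compound 2

The compounds below may be only part of what the source reports. "The series", "measured", "known", "first", "only" and "open" are said of these compounds alone.

Compound 2, with structure `N#Cc1c(Nc2ccccc2)nc(SCC(=O)Nn2c(COc3ccc(Cl)cc3Cl)nc3ccccc3c2=O)nc1-c1ccccc1`, is tested in a functional assay on the whole organism (strain albino) for inhibition, with Rattus norvegicus as the target, read by paw edema, with stated times of 1 h and 0.5 h, at a dose of 100 mg/kg by the oral route (a higher number here means more inhibition at the dose given (going by the name of the read-out), a lower number less inhibition), and gives 71.2%. That number lies within the scatter of compound 1, whose structure is `N#Cc1c(Cl)nc(SCC(=O)Nn2c(COc3ccc(Cl)cc3Cl)nc3ccccc3c2=O)nc1-c1ccc(Cl)cc1` and which gives 61.5%. Compound 3, with structure `N#Cc1c(Nc2ccc(Cl)cc2)nc(SCC(=O)Nn2c(COc3ccc(Cl)cc3Cl)nc3ccccc3c2=O)nc1-c1ccccc1`, gives 51.9%, a number that lies beyond the scatter of compound 2. Compound 4 has structure `N#Cc1c(Nc2ccccc2)nc(SCC(=O)Nn2c(COc3ccc(Cl)cc3Cl)nc3ccccc3c2=O)nc1-c1ccc(Cl)cc1` and has not yet been measured. It differs from compound 2 by chloro in place of hydrogen on an aromatic carbon. Among the measured compounds shown here, the one measured step of this kind is a number 19.3 percentage points lower from compound 2 to compound 3 (beyond the scatter), a chloro added on an aromatic carbon of a different ring. A similar modest drop is therefore expected, roughly a number 13.2 percentage points lower from compound 2 to compound 4 (beyond the scatter). Compound 4 is estimated to give 58%, between 42% and 74%.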

Compound 4, a percentage reported as inhibition, in the whole organism at one dose (the size of the read-out at that dose, not a potency): 36.5%
Compound 4: middle estimate off by 21.5 percentage points, on the high side; measured number outside the range, below it.
By their numbers in this assay, from the lowest: compound 4; then compounds 3, 1 and 2 (each within the scatter of the next, the first and the last beyond it).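

In this assay, the change from phenyl to 4-chlorophenyl costs more than the earlier chloro on the anilino ring: the new step, a number 34.7 percentage points lower from compound 2 to compound 4 (beyond the scatter), is large, whereas a number 19.3 percentage points lower from compound 2 to compound 3 (beyond the scatter) is modest. With the 4-chlorophenyl kept, anilino in place of chloro gives a number 25 percentage points lower from compound 1 to compound 4 (beyond the scatter), so that swap does not bring inhibition back in this series. Nothing available explains why this position responds so strongly. Going by these compounds, whether a fluoro or a methoxy at this same place would cost as much remains open, and so does whether the loss is specific to chlorine.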